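This account rests on a few compounds, and the source may have more. Where it says the series, first, only, none or still open, it means among the compounds named here.

Working notes on the series. Compound 2 `COc1cc(-c2nnc3n2NC(c2ccco2)C(C(=O)c2cccs2)S3)cc(OC)c1OC` carries a (thiophen-2-yl)carbonyl on the shared core; in a functional assay on MCF7 cells (Homo sapiens) for cytotoxicity, read by MTT assay, with a stated time of 48 h (on this read-out higher numbers stand for weaker inhibition and lower numbers for stronger inhibition), compound 2 returns only a limit, > 100000 nM, and no number. Compound 1 `COc1cc(-c2nnc3n2NC(c2ccco2)C(C(=O)c2ccccc2F)S3)cc(OC)c1OC` gives 94800 nM in this assay. Compound 3 `COc1cc(-c2nnc3n2NC(c2ccco2)C(C(=O)c2ccc(C(F)(F)F)cc2)S3)cc(OC)c1OC` gives 33600 nM in this assay. Compound 4 `COc1cccc(C(=O)C2Sc3nnc(-c4cc(OC)c(OC)c(OC)c4)n3NC2c2ccco2)c1` is not yet measured; it differs from compound 2 in one place: 3-methoxyphenyl in place of thiophen-2-yl on a carbonyl carbon.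

The measured step that bears most directly on this change is an at least 2.9-fold lower number from compound 2 to compound 3 (0.47 log units; beyond the scatter), which likewise puts a six-membered aromatic ring of carbon only where thiophen-2-yl stood. In the same direction, a 2.8-fold lower number from compound 1 to compound 3 (0.45 log units; beyond the scatter), while an at least 1.0-fold higher number from compound 1 to compound 2 (0.02 log units; that floor lies within the scatter). On this basis the exchange of thiophen-2-yl for 3-methoxyphenyl is expected to give a modest step to a lower number in this assay, with a real chance that the result again sits at the limit, as with the limit of > 100000 nM in this assay, at which 1 of the 3 values shown sits.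

Compound 4 is therefore estimated at 50000 nM, within the range 20000 nM to 120000 nM. This estimate corresponds to an expected step of an at least 2.0-fold lower number from compound 2 to compound 4 (0.30 log units; that floor lies within the scatter).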

Compound 4, half-maximal inhibitory concentration: > 100000 nM
Compound 4 was reported as a limit; the forecaster's own chance of this, stated with the estimate: 30%; at least 2.0-fold (0.30 log units) between middle value and limit.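

Ring type alone does not bring the number down at this position in this assay: replacing 4-(trifluoromethyl)phenyl with 3-methoxyphenyl on the carbonyl carbon gives an at least 2.9-fold higher number from compound 3 to compound 4 (0.47 log units; beyond the scatter), so a six-membered aromatic ring of carbon only is not enough to reproduce the lower number of compound 3. Against 2-fluorophenyl, the same group gives an at least 1.0-fold higher number from compound 1 to compound 4 (0.02 log units; that floor lies within the scatter), which sets no order between compound 1 and compound 4. Compound 4 is reported only as a limit, as is compound 2, so the step between them cannot be read, and the limit now takes in more of the series: the limit of > 100000 nM in this assay, at which 2 of the 4 values shown sit.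

The compounds shown leave open whether the lower number of compound 3 depends on the trifluoromethyl group itself or on where it sits on the ring. They also leave open how an amine or a carboxylic acid on this ring would read out.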